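Chloro in Place of Fluoro on the Furan-3-yl Compound

A few compounds are considered here, and "the series" means these few. Any claim that something is new, unique, unknown or untested is made for them only; others in the source may bear on it.

In a functional assay on DU-145 cells (Homo sapiens), read by sulforhodamine B assay, with a stated time of 5 days (on this read-out lower numbers stand for stronger inhibition of growth and higher numbers for weaker inhibition of growth), compound 1 `OC[C@H]1O[C@@H](n2cc(F)c3c(-c4c[nH]cn4)ncnc32)[C@H](O)[C@@H]1O` gives 890 nM, while compound 2 `OC[C@H]1O[C@@H](n2cc(F)c3c(-c4ccoc4)ncnc32)[C@H](O)[C@@H]1O` gives 5 nM, the lower of the two numbers. Among the compounds with values here, the only measured step, a 180-fold lower number from compound 1 to compound 2 (2.25 log units; beyond the scatter), is large and beyond the scatter, but it concerns furan-3-yl in place of 1H-imidazol-4-yl, not the halogen. Compound 3 `OC[C@H]1O[C@@H](n2cc(Cl)c3c(-c4ccoc4)ncnc32)[C@H](O)[C@@H]1O` has chloro in place of fluoro on an aromatic carbon. Within the data shown here, no measured step touches that place, so no shift beyond the scatter is expected in this assay. The estimated change is a 1.4-fold higher number from compound 2 to compound 3 (0.15 log units; within the scatter). For compound 3 the expected value is 7 nM, with an estimated range of 2 nM to 30 nM.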

Compound 3, concentration for 50% growth inhibition: 54 nM
Estimate against measurement, compound 3: 7.7-fold (0.89 log units) below; the whole stated range lies below it.
By their numbers in this assay, from the lowest: compound 2; then compound 3; then compound 1.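

Chloro in place of fluoro gives an 11-fold higher number from compound 2 to compound 3 (1.03 log units; beyond the scatter) in this assay. The earlier compounds shown here differed only in the furan-3-yl and 1H-imidazol-4-yl groups, whereas this step shows that the halogen place also moves the number, even though one heavy atom replaces another and the counted hydrogen-bond donors, acceptors and net charge stay the same. No measurement at hand gives a reason for the shift.

Open, as far as these compounds go, is how a methyl, a nitrile or an amine on this carbon would read in this assay. Also open, from the compounds shown here alone, is whether chloro shifts the number similarly alongside 1H-imidazol-4-yl.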